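Benzyl to allyl on a hydroxyurea 5-lipoxygenase inhibitor

A few compounds are considered here, and "the series" means these few. Any claim that something is new, unique, unknown or untested is made for them only; others in the source may bear on it.

Measured compounds:
compound 1 `NC(=S)N(O)CC1=Cc2cc(Oc3ccccc3)ccc2OC1`, 200 nM
compound 2 `O=C(NCc1ccccc1)N(O)CC1=Cc2cc(Oc3ccccc3)ccc2OC1`, 440 nM

Among the measured compounds shown here, in an assay (Cavia porcellus) for inhibition of Polyunsaturated fatty acid 5-lipoxygenase (Homo sapiens) (a higher number here means a weaker inhibitor, a lower number a stronger inhibitor), compound 2 gives the higher of the two numbers, with compound 1 the only neighbour by a 2.2-fold higher number from compound 1 to compound 2 (0.34 log units; beyond the scatter). Compound 3 `C=CCNC(=O)N(O)CC1=Cc2cc(Oc3ccccc3)ccc2OC1` differs from compound 2 by vinyl in place of phenyl on a saturated chain carbon bound to an amide-type nitrogen. For the measured compounds named here, the one measured step alters the substituent on the amine nitrogen instead, so no step here bears directly on this change; the estimate therefore leans on compound 2 alone. Compound 3 is expected to stay near compound 2, an estimated 1.1-fold lower number from compound 2 to compound 3 (0.04 log units; within the scatter), giving 400 nM with a range from 150 nM to 1200 nM.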

Compound 3, half-maximal inhibitory concentration: 44 nM
Compound 3: the middle estimate sits 9.1-fold (0.96 log units) above what was measured, and the stated range ends above it.
By their numbers in this assay, from the lowest: compound 3; then compound 1; then compound 2.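

In this assay, vinyl in place of phenyl on a saturated chain carbon bound to an amide-type nitrogen brings a 10-fold lower number from compound 2 to compound 3 (1.00 log units; beyond the scatter), showing that this position responds strongly to the change from benzyl to allyl. The larger group on the amine nitrogen need not cost activity, as the allylcarbamoyl group gives a 4.5-fold lower number from compound 1 to compound 3 (0.66 log units; beyond the scatter), reversing the order seen with the benzylcarbamoyl group. No measurement here explains the gain.

As far as these compounds go, it remains open whether the gain follows from the double bond or from the loss of the ring. A saturated propyl chain or a methyl group in the same place would help separate the two.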